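A few compounds are considered here, and "the series" means these few. Any claim that something is new, unique, unknown or untested is made for them only; others in the source may bear on it.

Measured so far:
Compound 1 `Cc1ccc([S+]([O-])c2ccccc2CN(C)C)c(N)c1` — in an assay on isolated protein for inhibition of sodium-dependent dopamine transporter (Homo sapiens) (on this read-out lower numbers stand for stronger inhibition and higher numbers for weaker inhibition), compound 1 reaches only a limit of the assay, > 100 nM.
Compound 2 `Cc1ccc(S(=O)(=O)c2ccccc2CN(C)C)c(N)c1` — in this assay compound 2 likewise reaches only a limit, > 100 nM.
Compound 3 `CCN(c1ccc(C)cc1N)c1ccccc1CN(C)C` — in this assay compound 3 again reaches only a limit, > 100 nM.

Compound 3 therefore has no fixed place among the numbers shown: all three values are limits (the limit of > 100 nM in this assay, at which 3 of the 3 values shown sit), so no order among compound 1, compound 2 and compound 3 can be read, and no step between measured compounds exists. The three compounds differ in the linker that joins the two aromatic rings; compound 3 carries an ethyl on the nitrogen of that linker.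

Compound 4 `Cc1ccc(N(Cc2ccccc2)c2ccccc2CN(C)C)c(N)c1` changes compound 3 in one place: phenyl in place of methyl on a saturated chain carbon bound to a nitrogen on an aromatic ring; cut one bond further out, this reads ethyl to benzyl. Among the measured compounds shown here, no measured step bears on this change, and the three limits give no direction to extrapolate. In this assay a step within or only slightly beyond the usual scatter is expected, direction undetermined, with a real chance that compound 4 also returns a limit rather than a number.

For compound 4 the estimated value is 300 nM, within 60 nM to 3000 nM, which corresponds to an expected step that the limit leaves unreadable from compound 3 to compound 4.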

Compound 4, half-maximal inhibitory concentration: > 100 nM
Compound 4 was reported as a limit (the forecaster's own chance of this, stated with the estimate: 60%); the middle value is on the limit's open side.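

No new step can be read between compound 3 and compound 4 in this assay, as both stand at a limit of the assay: the limit of > 100 nM in this assay, at which 4 of the 4 values shown sit.

On these data alone, whether compound 1, compound 2, compound 3 and compound 4 differ at all in this assay stays open, and so does the effect of ethyl to benzyl on inhibition.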